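Replacing oxan-4-yl on the aromatic nitrogen

A few compounds are considered here, and "the series" means these few. Any claim that something is new, unique, unknown or untested is made for them only; others in the source may bear on it.

Of the compounds shown here, two have numbers so far. In a functional assay on MDA-MB-231 cells (Homo sapiens) for inhibition, read by MTT assay, with a stated time of 5 days (a lower number here means a stronger inhibitor, a higher number a weaker inhibitor), compound 1 (`Cc1cc(Nc2nc(NCc3ccc(Cl)cc3)nc3[nH]ncc23)n[nH]1`) gives 7500 nM. Compound 2 (`Cc1cc(Nc2nc(NCc3ccc(Cl)cc3)nc3c2cnn3C2CCOCC2)n[nH]1`) gives 9420 nM, within the scatter of compound 1, so the two cannot be ranked.

Compound 3 (`Cc1cc(Nc2nc(NCc3ccc(Cl)cc3)nc3c2cnn3CC(C)(C)O)n[nH]1`) carries 2-hydroxy-2-methylpropyl in place of oxan-4-yl on an aromatic nitrogen. Among the measured compounds shown here, only one measured step bears on this change: a 1.3-fold higher number from compound 1 to compound 2 (0.10 log units; within the scatter). That step put oxan-4-yl in place of hydrogen on an aromatic nitrogen and stayed within the scatter. For the measured compounds named here, it is thin evidence, since no measured compound has an open chain at this place and none tests the hydroxy group. Still, the one substitution measured here left this assay essentially flat, so no change beyond the scatter is expected. The expected step is a 1.2-fold lower number from compound 2 to compound 3 (0.07 log units; within the scatter). Going by the values given here, the range is kept wide because a single step of a 1.3-fold higher number from compound 1 to compound 2 (0.10 log units; within the scatter) is the only guide. The estimated value for compound 3 is 8000 nM, with an expected range of 3500 nM to 18000 nM.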

Compound 3, half-maximal inhibitory concentration: 3980 nM
Beside the measured number, compound 3's estimate is 2.0-fold (0.30 log units) above it, within the range that was stated.
By their numbers in this assay, from the lowest: compounds 3, 1 and 2 (each within the scatter of the next, the first and the last beyond it).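

At this aromatic nitrogen, the choice of substituent now shows up in this assay as a 2.4-fold lower number from compound 2 to compound 3 (0.37 log units; beyond the scatter) and is the only step among these compounds that lies beyond the scatter, though it is modest. Set against hydrogen at the same place, 2-hydroxy-2-methylpropyl gives a 1.9-fold lower number from compound 1 to compound 3 (0.28 log units; within the scatter) and cannot be ranked, so the difference holds only against oxan-4-yl and does not show that substitution at this nitrogen helps in itself. The exchange removes a ring and adds a hydrogen-bond donor in a single step, and no measurement is available that accounts for the difference.

Still open, as far as these compounds go, is which of these two differences matters: 2-methoxy-2-methylpropyl would keep the open chain without the hydroxy hydrogen, while 4-hydroxycyclohexyl would keep a ring and carry a hydroxy group. Also open, from the compounds shown here alone, is how this assay responds to a primary amine or a carboxylic acid at this nitrogen, or to a longer chain ending in a hydroxy group.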